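The compounds below may be only part of what the source reports. "The series", "measured", "known", "first", "only" and "open" are said of these compounds alone.

Measured so far in a functional assay on A549 cells (Homo sapiens) for cytotoxicity, with a stated time of 48 h; on this read-out higher numbers stand for weaker inhibition and lower numbers for stronger inhibition:

compound 1 `CC(=O)Oc1ccc2oc(/C=C/[S+](C)[O-])cc(=O)c2c1` — 4100 nM
compound 2 `C[S+]([O-])/C=C/c1cc(=O)c2cc(F)ccc2o1` — 2100 nM
compound 3 `COc1cccc2c(=O)cc(/C=C/[S+](C)[O-])oc12` — 2200 nM

Compound 1 returns the highest of the three numbers in this assay, but neither gap is a real one: compound 3 sits a little lower, and the step of a 2.0-fold lower number from compound 1 to compound 2 (0.29 log units; within the scatter) is within the scatter, so the three compounds are not separable on these data.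

Compound 4 `CCC(=O)Oc1ccc2oc(/C=C/[S+](C)[O-])cc(=O)c2c1` is the next member. Relative to compound 1 it carries methyl in place of hydrogen on a saturated chain carbon bound to a carbonyl carbon — in other words acetoxy becomes propanoyloxy on the shared core, while the rest of compound 1 is kept.

For the measured compounds named here, no measured step touches this position. Going by the values given here, the single step on record, a 2.0-fold lower number from compound 1 to compound 2 (0.29 log units; within the scatter), exchanges the whole acetoxy for fluoro on an aromatic carbon and stays within the scatter; it says nothing about lengthening the acyl chain. Compound 3 differs from compound 1 in two places and offers no one-step comparison either. Among the compounds with values here, with no precedent for the change and the only known step being flat, the expectation for compound 4 is a number close to that of compound 1, with no shift beyond the scatter in either direction: the estimated step is a 1.0-fold lower number from compound 1 to compound 4 (0.01 log units; within the scatter).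

The value estimated for compound 4 in this assay is 4000 nM, with a range from 1800 nM to 9000 nM.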

Compound 4, half-maximal inhibitory concentration: 2400 nM
Beside the measured number, compound 4's estimate is 1.7-fold (0.22 log units) above it; measured number inside the range.
By their numbers in this assay, from the lowest: compounds 2, 3, 4 and 1 (each within the scatter of the next).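

On the shared core, acetoxy and propanoyloxy cannot be told apart in this assay (a 1.7-fold lower number from compound 1 to compound 4 (0.23 log units; within the scatter)), so this position now has a one-step reading of its own: methyl in place of hydrogen on a saturated chain carbon bound to a carbonyl carbon brings no shift beyond the scatter. Propanoyloxy and fluoro on an aromatic carbon are not separated either (a 1.1-fold higher number from compound 2 to compound 4 (0.06 log units; within the scatter)), so acetoxy, fluoro and propanoyloxy all lie within the scatter at this place on the core, and none of them can be ranked above another. Nothing available bears on why the numbers stay this close, and no reason can be offered for this result.

What remains open is whether this flat picture extends beyond the short acyl chains shown, for example to a longer chain such as hexanoyloxy or a branched one such as pivaloyloxy. Going by these compounds, it is equally open whether a chain ending in an amine or a carboxylic acid would move the number in this assay beyond the scatter in either direction.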